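Thiosemicarbazide series: ring size at the thiocarbonyl

This account rests on a few compounds, and the source may have more. Where it says the series, first, only, none or still open, it means among the compounds named here.

Measured compounds:
compound 2 `Cc1ccnc(/C(N)=N/NC(=S)N2CCCCC2)c1` — 18800 nM
compound 1 `Cc1ccnc(/C(N)=N/NC(=S)N2CCOCC2)c1` — a limit, > 100000 nM

Among the measured compounds shown here, compound 2 is the only compound of the pair with a number in a functional assay on MCF7 cells (Homo sapiens) for cytotoxicity, read by MTT assay, with a stated time of 72 h (a lower number here means a stronger inhibitor, a higher number a weaker inhibitor), where compound 2 gives 18800 nM. Compound 1 reaches only a limit in this assay, namely (the limit of > 100000 nM in this assay, at which 1 of the 2 values shown sits). For the measured compounds named here, the single measured step, an at least 5.3-fold lower number from compound 1 to compound 2 (0.72 log units; beyond the scatter), concerns the exchange of one hetero atom in the six-membered ring and says nothing about ring size.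

Compound 3 `Cc1ccnc(/C(N)=N/NC(=S)N2CCCC2)c1` differs from compound 2 by pyrrolidin-1-yl in place of piperidin-1-yl on a thiocarbonyl carbon. Going by the values given here, no measured step bears directly on this contraction, since the only step on record changes the ring's hetero atom content rather than its size. The expectation is therefore a step within the scatter, a 1.3-fold higher number from compound 2 to compound 3 (0.12 log units; within the scatter), in no particular direction. Compound 3 is thus estimated at 25000 nM in this assay, with a range from 8000 nM to 80000 nM.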

Compound 3, half-maximal inhibitory concentration: 1200 nM
The estimate for compound 3 lay 21-fold (1.32 log units) above the measured number; measured number below the stated range.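

Ring size at the thiocarbonyl carbon turns out to matter in this assay: going from the six-membered to the five-membered ring, with the ring's single hetero atom unchanged, gives a 16-fold lower number from compound 2 to compound 3 (1.19 log units; beyond the scatter), so this position responds to more than the exchange of a hetero atom. Measured against the morpholin-4-yl group, the pyrrolidin-1-yl group gives an at least 83-fold lower number from compound 1 to compound 3 (1.92 log units; beyond the scatter). Compound 1 stands at a limit, not at a number: the limit of > 100000 nM in this assay, at which 1 of the 3 values shown sits.

On these data alone, three ring amines cannot show whether the trend with ring size continues, so the response to a seven-membered azepan-1-yl ring or an open-chain dimethylamino group on the thiocarbonyl carbon remains open. Equally open, as far as these compounds go, is whether a methyl or hydroxyl group on the pyrrolidine ring would be tolerated.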